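Methyl in place of fluoro: notes on compound 3

A few compounds are considered here, and "the series" means these few. Any claim that something is new, unique, unknown or untested is made for them only; others in the source may bear on it.

Measured so far:
compound 1, `COC(=O)c1cc(-c2csc(N/N=C/c3cccs3)n2)ccc1OCc1ccccc1`, in a functional assay, read by spectrophotometry, with a stated time of 15 min, tested at 40 ug/mL (on this read-out higher numbers stand for a stronger effect at the one concentration tested and lower numbers for a weaker effect), gives 82.8%;
compound 2, `Fc1ccc(-c2csc(N/N=C/c3ccc(Cl)cc3Cl)n2)cc1`, in this assay gives 90%.

Compound 2 holds the upper of the two numbers shown, but its gap to compound 1 lies within the scatter, so the two cannot be told apart on these data. Within the data shown here, no step between measured compounds that differ in a single place is available, so nothing is yet known about how a single change at this position moves the read-out.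

Compound 3, `Cc1ccc(-c2csc(N/N=C/c3ccc(Cl)cc3Cl)n2)cc1`, has not been measured. It differs from compound 2 by methyl in place of fluoro on an aromatic carbon, that is 4-fluorophenyl to 4-methylphenyl. Among the measured compounds shown here, with both measured compounds near the top of the scale and no single-change step to lean on, the step of a number 5 percentage points lower from compound 2 to compound 3 (within the scatter) is expected to be none beyond the scatter. Compound 3 is therefore estimated at 85%, within 70% to 95%.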

Compound 3, a percentage reported as inhibition, at one concentration (the size of the read-out at that concentration, not a potency): 80.4%
Estimate against measurement, compound 3: 4.6 percentage points above, within the range that was stated.
By their numbers in this assay, from the lowest: compounds 3, 1 and 2 (each within the scatter of the next).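

In this assay the position now has its first single-change step, a number 9.6 percentage points lower from compound 2 to compound 3 (within the scatter), for methyl in place of fluoro on an aromatic carbon, para to a large group. On these data, 4-fluorophenyl and 4-methylphenyl cannot be told apart, so this exchange of one heavy atom for another shows no effect beyond the scatter, with the rest of the structure held constant. Nothing measured here bears on the reason for this result.

From the compounds shown here alone, whether a different kind of group at this place, such as an amine, a carboxylic acid or a longer chain, would move the read-out beyond the scatter remains open. Going by these compounds, the read-out comes from one concentration, so it also remains open whether compound 2 and compound 3 would show a stronger or weaker effect relative to each other at any other concentration.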